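Replacing the Heptyl Chain in Compound 3

The compounds below may be only part of what the source reports. "The series", "measured", "known", "first", "only" and "open" are said of these compounds alone.

Measured compounds:
compound 1 `O=c1cc(Cn2cc(CCO)nn2)c2ccc(O)cc2o1` — > 100000 nM
compound 2 `CCCCCCc1cn(Cc2cc(=O)oc3cc(O)ccc23)nn1` — > 100000 nM
compound 3 `CCCCCCCCc1cn(Cc2cc(=O)oc3cc(O)ccc23)nn1` — 50900 nM

In a functional assay on SW-620 cells (Homo sapiens) for inhibition, read by MTT assay, with a stated time of 72 h (on this read-out lower numbers stand for stronger inhibition and higher numbers for weaker inhibition), compound 1 gives > 100000 nM, which is a limit of the assay, not a number. Compound 2 likewise gives > 100000 nM, again a limit. Going by the values given here, compound 3 is the one compound with a number, giving 50900 nM in this assay. The step that the two limits leave unreadable from compound 1 to compound 2 therefore cannot be read. The steps of an at least 1.9-fold lower number from compound 1 to compound 3 (0.29 log units; that floor lies within the scatter) and an at least 1.9-fold lower number from compound 2 to compound 3 (0.29 log units; that floor lies within the scatter) show a floor only, and that floor sits within the scatter; this is as far as the limit of > 100000 nM in this assay, at which 2 of the 3 values shown sit, lets the three compounds be compared.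

Compound 4 `O=c1cc(Cn2cc(CSC(=S)N3CCNCC3)nn2)c2ccc(O)cc2o1` differs from compound 3 by a group of 9 heavy atoms (5 carbon, 2 nitrogen, 2 sulfur; one six-membered non-aromatic ring with 2 hetero atoms) in place of a group of 7 heavy atoms (7 carbon; no ring), on a saturated chain carbon bound to an aromatic carbon. Among the compounds with values here, none of the measured steps concerns a change of this kind, as all three vary the length of a plain chain; nothing measured bears directly on it, so no direction can be drawn from them. Compound 4 is expected to lie near compound 3, with a 1.0-fold lower number from compound 3 to compound 4 (0.01 log units; within the scatter) as the estimated step. The estimate for compound 4 is 50000 nM, within 8000 nM to 150000 nM.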

Compound 4, half-maximal inhibitory concentration: > 100000 nM
Compound 4: only a limit was reported (the forecaster's own chance of this, stated with the estimate: 45%); at least 2.0-fold (0.30 log units) between middle value and limit.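

Going by these compounds alone, the one change here away from a plain chain, a group with a six-membered non-aromatic ring with 2 hetero atoms in place of heptyl on a saturated chain carbon bound to an aromatic carbon, gives an at least 1.9-fold higher number from compound 3 to compound 4 (0.29 log units; that floor lies within the scatter). That is a floor only, so this assay does not tell how far compound 4 stands from compound 3, and it gives no sign that this ring-bearing group does better than heptyl. The other new steps, those reaching compound 4 from compound 1 and from compound 2, cannot be read, and the comparison ends at the same limit: the limit of > 100000 nM in this assay, at which 3 of the 4 values shown sit.

As far as these compounds go, whether any group at this place can give a lower number than compound 3 stays open. How a longer chain than heptyl, an amine or a carboxylic acid there would read in this assay is also unanswered by the compounds shown.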